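Swapping a methylpyridine amide for a fluorophenyl amide

This account rests on a few compounds, and the source may have more. Where it says the series, first, only, none or still open, it means among the compounds named here.

Compound 3 `Cc1cccc(C(=O)N[C@H]2CCC[C@H](NC(=O)c3cccc(Cl)c3)C2)n1` gives 290 nM in a functional assay on HEK293 cells for antagonist activity at metabotropic glutamate receptor 5 (Homo sapiens), read by FLIPR and calcium flux (a lower number here means a stronger inhibitor, a higher number a weaker inhibitor), the lowest of the two numbers in hand. Compound 2 `O=C(N[C@H]1CCC[C@H](NC(=O)c2cccc(Cl)c2)C1)c1cccnc1` gives 612 nM, so that a 2.1-fold lower number from compound 2 to compound 3 (0.32 log units; beyond the scatter). Compound 1 `O=C(N[C@H]1CCC[C@H](NC(=O)c2ccccn2)C1)c1cccc(Cl)c1` returns only a limit in this assay, > 10000 nM. Starting from compound 1, an at least 16-fold lower number from compound 1 to compound 2 (1.21 log units; beyond the scatter) and an at least 34-fold lower number from compound 1 to compound 3 (1.53 log units; beyond the scatter). Compound 4 `O=C(N[C@H]1CCC[C@H](NC(=O)c2cccc(Cl)c2)C1)c1ccc(F)cc1` differs from compound 3 by 4-fluorophenyl in place of 6-methylpyridin-2-yl on a carbonyl carbon. Among the compounds with values here, no measured step replaces the nitrogen-containing ring with a carbon-only ring, but both steps away from the plain pyridin-2-yl amide were large and lowered the number, while the gap between compound 2 and compound 3 was modest. A moderate rise in the number is therefore expected, a 1.7-fold higher number from compound 3 to compound 4 (0.24 log units; within the scatter). Compound 4 is estimated at 500 nM, within 120 nM to 2500 nM.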

Compound 4, half-maximal inhibitory concentration: 194 nM
For compound 4 the middle estimate is 2.6-fold (0.41 log units) above the measured one; the measured number falls inside the stated range.
By their numbers in this assay, from the lowest: compounds 4 and 3 (each within the scatter of the next); then compound 2. At a limit, above all of these: compound 1.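

In this assay, the change to 4-fluorophenyl gives a 1.5-fold lower number from compound 3 to compound 4 (0.17 log units; within the scatter), so a ring nitrogen is not required on this carbonyl carbon for a number of this size. Set against pyridin-3-yl, the same ring gives a 3.2-fold lower number from compound 2 to compound 4 (0.50 log units; beyond the scatter). Set against pyridin-2-yl, it gives an at least 51-fold lower number from compound 1 to compound 4 (1.71 log units; beyond the scatter), but that step starts from a limit: the limit of > 10000 nM in this assay, at which 1 of the 4 values shown sits.

The compounds shown leave open what the fluorine adds compared with a plain phenyl ring. They also leave open how a longer chain or a carboxylic acid on this carbonyl carbon would read.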